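The compounds below may be only part of what the source reports. "The series", "measured", "known", "first", "only" and "open" are said of these compounds alone.

Compound 1 `O=C1C(=O)N(CN2CCN(c3ccnc4cc(C(F)(F)F)ccc34)CC2)c2cc(Br)ccc21` and compound 2 `O=C1C(=O)N(CN2CCN(c3ccnc4cc(C(F)(F)F)ccc34)CC2)c2ccccc21` share one core, while compound 3 `NC(=S)N/N=C1/C(=O)N(CN2CCN(c3ccnc4cc(Cl)ccc34)CC2)c2cc(Br)ccc21` and compound 4 `NC(=S)N/N=C1/C(=O)N(CN2CCN(c3ccnc4cc(Cl)ccc34)CC2)c2ccccc21` share another; the difference between the two cores is not broken down here. In a functional assay on MDA-MB-468 cells (Homo sapiens) for cytotoxicity, read by sulforhodamine B assay, with a stated time of 48 h (a higher number here means a weaker inhibitor of growth, a lower number a stronger inhibitor of growth), compound 1 gives 24800 nM, compound 2 gives 15300 nM and compound 3 gives 11200 nM. The change hydrogen in place of bromo on an aromatic carbon produced a step of a 1.6-fold lower number from compound 1 to compound 2 (0.21 log units; within the scatter). Compound 4 carries the same change on its own core, (hydrogen in place of bromo on an aromatic carbon). Because the measured step of a 1.6-fold lower number from compound 1 to compound 2 (0.21 log units; within the scatter) stayed within the scatter, a step of similar size is expected here as well, a 1.4-fold lower number from compound 3 to compound 4 (0.15 log units; within the scatter). Compound 4 is therefore estimated at 8000 nM in this assay, with 3500 nM and 20000 nM as the bounds of that expectation.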

Compound 4, concentration for 50% growth inhibition: 20600 nM
Compound 4: middle estimate off by 2.6-fold (0.41 log units), on the low side; the measured number lies above the stated range.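

In this assay, hydrogen in place of bromo on an aromatic carbon gave a 1.8-fold higher number from compound 3 to compound 4 (0.26 log units; within the scatter). Set beside the earlier step on the other core, the two steps run in opposite directions and stand apart: the same change on two cores in this assay, a 1.6-fold lower number (0.21 log units; within the scatter) from compound 1 to compound 2 and a 1.8-fold higher number (0.26 log units; within the scatter) from compound 3 to compound 4, 3.0-fold (0.47 log units) apart, beyond the scatter of two such steps. This shows that, in these two pairs, the change did not carry over from one core to the other with the same direction and size, but two pairs cannot establish a rule for the series or show what lies behind the split.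

Left open is how an amine or a methoxy group on that aromatic carbon would behave on either core. Also open, going by these compounds, is which part of the difference between the two cores goes with the split.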